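Aryl group variation on the ring amide nitrogen

The compounds below may be only part of what the source reports. "The series", "measured", "known", "first", "only" and "open" are said of these compounds alone.

Measured compounds and their values:
- compound 1, `CC(C)[C@@H]1CC[C@@H](C)C[C@@]12N(C)C(=O)[C@@H]1[C@H]3C(=O)N(c4ccc(Cl)cc4)C(=O)[C@H]3ON12`: 53.1%
- compound 2, `Cc1cccc(N2C(=O)[C@H]3[C@H](ON4[C@@H]3C(=O)N(C)[C@@]43C[C@H](C)CC[C@H]3C(C)C)C2=O)c1`: 57.6%

In a functional assay, with a stated time of 20 min, tested at 2.5 mg/mL (a higher number here means a stronger effect of the compound at the concentration tested, a lower number a weaker effect), compound 1 gives 53.1% and compound 2 gives 57.6%. Compound 2 holds the higher of the two numbers, but the step of a number 4.5 percentage points higher from compound 1 to compound 2 (within the scatter) is within the scatter, so the two values are not distinguishable.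

Compound 3, `Cc1ccc(N2C(=O)[C@H]3[C@H](ON4[C@@H]3C(=O)N(C)[C@@]43C[C@H](C)CC[C@H]3C(C)C)C2=O)c(C)c1`, is not yet measured in this assay. It differs from compound 2 in one place: 2,4-dimethylphenyl in place of 3-methylphenyl on an amide-type nitrogen in a ring. Going by the values given here, the only measured step that bears on this change is the exchange of the aryl group on the same ring nitrogen, a number 4.5 percentage points higher from compound 1 to compound 2 (within the scatter), which produced no effect beyond the scatter. On that basis the step of a number 0.6 percentage points lower from compound 2 to compound 3 (within the scatter) is expected to stay within the scatter as well, in no particular direction.

Compound 3 is therefore estimated to give 57% in this assay, with a range from 44% to 70%.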

Compound 3, a percentage reported as activity, at one concentration (the size of the read-out at that concentration, not a potency): 77.1%
Beside the measured number, compound 3's estimate is 20.1 percentage points below it; the measured number lies above the stated range.
By their numbers in this assay, from the lowest: compounds 1 and 2 (each within the scatter of the next); then compound 3.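

In this assay, the aryl group on the amide-type nitrogen in a ring now proves able to change the read-out: 2,4-dimethylphenyl in place of 3-methylphenyl gives a number 19.5 percentage points higher from compound 2 to compound 3 (beyond the scatter), although both groups are six-membered aromatic rings of carbon only, with no hydrogen-bond donors or acceptors and no net charge. The same group in place of 4-chlorophenyl gives a number 24 percentage points higher from compound 1 to compound 3 (beyond the scatter), so compound 3 stands clear of both earlier compounds, which remain within the scatter of each other and therefore gave no sign that this position mattered. No measurement shown offers an explanation for the rise.

Going by these compounds, with three aryl groups on this nitrogen, it remains open whether the rise in this assay needs both methyl groups of 2,4-dimethylphenyl or would also appear with 2-methylphenyl or 4-methylphenyl alone. Also open, on these data alone, is how the read-out would respond to a methoxy group, an amine or a carboxylic acid on the same aryl ring, or to a longer chain in place of the methyl groups.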